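A few compounds are considered here, and "the series" means these few. Any claim that something is new, unique, unknown or untested is made for them only; others in the source may bear on it.

Measured so far in an assay for inhibition of Fatty-acid amide hydrolase 1 (Rattus norvegicus); on this read-out higher numbers stand for weaker inhibition and lower numbers for stronger inhibition:

Compound 1 `NC(=O)c1ccc(-c2cnc(C(O)CCc3ccc(-c4ccccc4)cc3)o2)nc1` gives > 1000 nM, which is a limit of the assay rather than a number.
Compound 2 `NC(=O)c1ccc(-c2cnc(CCCc3ccc(-c4ccccc4)cc3)o2)nc1` gives 30000 nM.

Compound 1 thus stands only at a limit, and no number places it among the values shown. Compound 3 `NC(=O)c1cccc(-c2cnc(C(O)CCc3ccc(-c4ccccc4)cc3)o2)n1` has the same atoms as compound 1, joined differently: 6-carbamoylpyridin-2-yl in place of 5-carbamoylpyridin-2-yl on an aromatic carbon. Within the data shown here, the only measured step, a step that the limit leaves unreadable from compound 1 to compound 2, changes a different part of the molecule, and its size cannot be read because the limit of > 1000 nM in this assay, at which 1 of the 2 values shown sits, hides it. Among the measured compounds shown here, no measured step therefore bears on shifting the carbamoyl group within the pyridin-2-yl group, and neither the size nor the direction of such a change in this assay can be taken from the data. For compound 3 the expected value is 5000 nM, with a range from 1000 nM to 30000 nM. This expectation amounts to an estimated step that the limit leaves unreadable from compound 1 to compound 3.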

Compound 3, inhibition constant: 20000 nM
Compound 3: middle estimate off by 4.0-fold (0.60 log units), on the low side, and the stated range covers the measured number.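

Among these compounds, no step from compound 1 to compound 3 can be read in this assay, because compound 1 stands at a limit of the assay rather than at a number: the limit of > 1000 nM in this assay, at which 1 of the 3 values shown sits. From the compounds shown here alone, whether 6-carbamoylpyridin-2-yl in place of 5-carbamoylpyridin-2-yl strengthens or weakens inhibition, and by how much, stays open.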